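From a 4-Bromophenyl to a 2,3-Dichlorophenyl Group

The compounds below may be only part of what the source reports. "The series", "measured", "known", "first", "only" and "open" are said of these compounds alone.

In an ADME assay on NHDF cells (Homo sapiens) for cytotoxicity, read by MTT assay, with a stated time of 72 h (a higher number here means a weaker inhibitor, a lower number a stronger inhibitor), compound 1 `COc1cccc(/C=C2\CCC/C(=C\c3ccc(Cl)cc3)C2=O)c1OC` gives 18600 nM and compound 2 `COc1cccc(/C=C2\CCC/C(=C\c3cccc(Br)c3)C2=O)c1OC` gives 23900 nM while compound 3 `COc1cccc(/C=C2\CCC/C(=C\c3ccc(Br)cc3)C2=O)c1OC` gives 21400 nM as its value. Compound 3 thus stands level with the other two, as all three lie within the usual scatter of repeated measurements.

Compound 4 `COc1cccc(/C=C2\CCC/C(=C\c3cccc(Cl)c3Cl)C2=O)c1OC` differs from compound 3 in one group (2,3-dichlorophenyl in place of 4-bromophenyl on a double-bonded chain carbon bound to a double-bonded ring carbon) on a double-bonded chain carbon bound to a double-bonded ring carbon. Among the compounds with values here, three measured steps bear on this change. Exchanging the halogen gave a 1.2-fold higher number from compound 1 to compound 3 (0.06 log units; within the scatter) and moving the bromo group gave a 1.1-fold lower number from compound 2 to compound 3 (0.05 log units; within the scatter) while exchanging the whole group gave a 1.3-fold higher number from compound 1 to compound 2 (0.11 log units; within the scatter) in the same series. Within the data shown here, no measured compound carries the 2,3-dichlorophenyl group, so the expected range has to stay wide.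

With measured steps this small, no step beyond the scatter is expected in this assay for this change. The expected step is a 1.1-fold lower number from compound 3 to compound 4 (0.03 log units; within the scatter) on this estimate. The estimate for compound 4 is 20000 nM with an expected range from 11000 nM to 36000 nM in this measurement.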

Compound 4, half-maximal inhibitory concentration: > 50000 nM
Compound 4 was reported as a limit (the forecaster's own chance of this, stated with the estimate: 5%); at least 2.5-fold (0.39 log units) between middle value and limit.
By their numbers in this assay, from the lowest: compounds 1, 3 and 2 (each within the scatter of the next). At a limit, above all of these: compound 4.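

Compound 4 is reported only as a limit of the assay, not as a number: the limit of > 50000 nM in this assay, at which 1 of the 4 values shown sits. Even so, in this assay the change can be read as a step beyond the scatter, with an at least 2.3-fold higher number from compound 3 to compound 4 (0.36 log units; beyond the scatter), an at least 2.0-fold higher number from compound 2 to compound 4 (0.32 log units; beyond the scatter) and an at least 2.6-fold higher number from compound 1 to compound 4 (0.42 log units; beyond the scatter). Compounds 1, 2 and 3, each with a single halogen on the phenyl group, stayed within the scatter of one another, so only compound 4 shows that the group on the double-bonded chain carbon bound to a double-bonded ring carbon can shift this number into a weaker reading.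

Going by these compounds, whether a 2-chlorophenyl or a 3-chlorophenyl group alone would already give such a step remains open. Also open, on these data alone, is how a phenyl group carrying an amine or a carboxylic acid would behave at this place.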